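Chloro in Place of Hexyloxy on a Shared Sulfonamide Core

The source may hold more compounds than are shown below. What is called first, only, known or untested is meant among the compounds shown, and "the series" means these compounds.

Measured compounds:
compound 1, `Cc1ccccc1NS(=O)(=O)c1ccc(N2CCNC2=O)cc1`
compound 2, `CCCCCCOc1ccc(NS(=O)(=O)c2ccc(N3CCNC3=O)cc2)cc1`

In a functional assay on MCF7 cells (Homo sapiens) for antiproliferative activity, read by sulforhodamine B assay, with a stated time of 48 h (a higher number here means a weaker inhibitor, a lower number a stronger inhibitor), compound 1 gives 280 nM. For compound 2 this assay reports only a limit, > 1000 nM, not a number. Within the data shown here, compound 2 therefore stands at the limit of > 1000 nM in this assay, at which 1 of the 2 values shown sits, and no measured step connects it to compound 1; the two values show only that compound 1 has a number while compound 2 does not.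

Compound 3, `O=C1NCCN1c1ccc(S(=O)(=O)Nc2ccc(Cl)cc2)cc1`, differs from compound 2 in one place: chloro in place of hexyloxy on an aromatic carbon. Among the measured compounds shown here, with no measured step to lean on, the direction of this change in this assay is open, but a step back into the numbered range, beyond the usual scatter, is expected, estimated as an at least 2.2-fold lower number from compound 2 to compound 3 (0.34 log units; beyond the scatter). The value for compound 3 is estimated at 450 nM, with a range from 120 nM to 2000 nM.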

Compound 3, half-maximal inhibitory concentration: 170 nM
Compound 3: middle estimate off by 2.6-fold (0.42 log units), on the high side; low and high end bracket the measured number.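

In this assay, among these compounds, chloro in place of hexyloxy on this aromatic carbon brings the series back into the numbered range, which the earlier compounds could not show for this position: an at least 5.8-fold lower number from compound 2 to compound 3 (0.76 log units; beyond the scatter). The size of this step has only one bound, as compound 2 carries a limit and not a number: the limit of > 1000 nM in this assay, at which 1 of the 3 values shown sits. The second step, a 1.6-fold lower number from compound 1 to compound 3 (0.22 log units; within the scatter), shows that compound 3 and compound 1 cannot be told apart in this assay, so 4-chlorophenyl and 2-methylphenyl on the sulfonamide nitrogen give values within the usual scatter of each other.

Going by these compounds, whether a shorter chain at this place, such as methoxy or butoxy, would read nearer compound 3 or compound 2 remains open. So does the outcome of a fluoro group or an amine in place of chloro.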